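The source may hold more compounds than are shown below. What is called first, only, known or untested is meant among the compounds shown, and "the series" means these compounds.

Compound 1, `Nc1ccccc1NC(=O)c1ccc(CSC(=S)N2CCN(Cc3ccccn3)CC2)cc1`: 20.7%
Compound 2, `Nc1ccccc1NC(=O)c1ccc(CSC(=S)N2CCN(C(c3ccccc3)c3ccccc3)CC2)cc1`: 8.7%
Compound 3, `Nc1ccccc1NC(=O)c1ccc(CSC(=S)N2CCc3cc(Cl)ccc32)cc1`: 31.9%

All three were tested in a functional assay on A-375 cells (Homo sapiens) for antiproliferative activity, read by CCK-8 assay, with a stated time of 72 h, tested at 2 uM; a higher number here means a stronger effect of the compound at the concentration tested, a lower number a weaker effect. On these numbers compound 1 stands second highest of the three: compound 3 sits higher, by a gap beyond the usual scatter, and compound 2 sits lower, also by a gap beyond the scatter. Compound 4, `Nc1ccccc1NC(=O)c1ccc(CSC(=S)N2CCN(c3ccncc3)CC2)cc1`, has not yet been measured. It differs from compound 1 in a single place: pyridin-4-yl in place of (pyridin-2-yl)methyl on an amine nitrogen in a ring. No step between two measured compounds mirrors this change, so there is no shown step to lean on. The counts show the leaving and entering groups alike in their ring, their hydrogen-bond donors and their acceptors, differing only slightly in size. The expected step from compound 1 to compound 4 is therefore a number 1.7 percentage points lower from compound 1 to compound 4 (within the scatter), which is read as no change beyond the scatter in either direction. Compound 4 is expected to give about 19% in this assay, with a likely range from 6% to 33%.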

Compound 4, a percentage reported as inhibition, at one concentration (the size of the read-out at that concentration, not a potency): 85.7%
Estimate against measurement, compound 4: 66.7 percentage points below, and the stated range ends below it.
By their numbers in this assay, from the lowest: compound 2; then compound 1; then compound 3; then compound 4.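

Replacing (pyridin-2-yl)methyl with pyridin-4-yl on the amine nitrogen in the ring gives, in this assay, a number 65 percentage points higher from compound 1 to compound 4 (beyond the scatter), a large step. The result shows that this position strongly affects the read-out, even though the two groups have the same ring and hydrogen-bond counts and differ only slightly in size, so those counts alone do not capture what matters in this change. No measurement shown here explains why the step is so large.

The change alters both the one-carbon link and the place of the ring nitrogen, so the compounds shown leave open which of these matters, or whether both do. Pyridin-2-yl and (pyridin-4-yl)methyl on the same nitrogen would separate the two, while pyridin-3-yl or plain phenyl would test the role of the ring nitrogen itself.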